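The source may report more compounds than this note shows. Statements on the series, on what has been measured and on what is new or still open speak of the compounds shown alone.

Measured so far:
compound 1, `COc1ccc(N(CC(=O)NCCC[Te]c2ccccc2)C(=O)CNC(=O)OC(C)(C)C)cc1`: 4.2
compound 2, `O=C(COC(=O)/C=C/c1ccccc1)NCCC[Te]c1ccccc1`: 3.01

In a physicochemical assay for lipophilicity, read by HPLC, measured as octanol-water partition (on this read-out higher numbers stand for higher lipophilicity and lower numbers for lower lipophilicity), compound 1 gives 4.2, the higher of the two numbers in hand; compound 2 gives 3.01, and the gap between the two is beyond the scatter. Within the data shown here, the two compounds differ in more than one place, so no single step can be read from them; the pair shows only that compound 1 sits higher in this assay than compound 2.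

Compound 3, `COc1ccc(N(CC(=O)NCCCSc2ccccc2)C(=O)CNC(=O)OC(C)(C)C)cc1`, is not yet measured in this assay. It differs from compound 1 in one place: a group of 7 heavy atoms (6 carbon, 1 sulfur; one six-membered aromatic ring of carbon only) in place of a group of 7 heavy atoms (6 carbon, 1 tellurium; one six-membered aromatic ring of carbon only), on a saturated chain carbon, three bonds along the chain from an amide-type nitrogen. The rest of compound 1 is kept unchanged. Among the measured compounds shown here, no measured pair shows this exchange, so the direction rests on the change alone. A fall in this assay of modest size is expected, larger than the scatter but clearly smaller than the gap between compound 1 and compound 2. The step expected from compound 1 to compound 3 is a number 0.70 log units lower from compound 1 to compound 3 (beyond the scatter). Compound 3 is expected at 3.5 in this assay, with a range from 3 to 4.1.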

Compound 3, partition coefficient: 3.12
Compound 3: the middle estimate sits 0.38 log units above what was measured; measured number inside the range.
By their numbers in this assay, from the lowest: compounds 2 and 3 (each within the scatter of the next); then compound 1.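

Among these compounds, compound 1 and compound 3 form the first pair that differs in one place, so the exchange can now be read directly: with the rest of compound 1 kept, phenylsulfanyl in place of the tellurium-containing group gives in this assay a number 1.08 log units lower from compound 1 to compound 3 (beyond the scatter). The two groups have the same count of heavy atoms and the same six-membered aromatic ring of carbon only, and they differ in sulfur against tellurium and in the count of hydrogen-bond acceptors, so at this place, on a saturated chain carbon, three bonds along the chain from an amide-type nitrogen, that exchange alone is enough for a large step. Nothing at hand accounts for the size of this step.

On these data alone, the step rests on this one pair, so it remains open whether the same exchange gives a similar step in this assay when made on compound 2, which carries the same tellurium-containing group. Also open, as far as these compounds go, is where a group with selenium or oxygen in place of tellurium would fall, and what a longer chain would do at this place.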